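The source may report more compounds than this note shows. Statements on the series, on what has been measured and on what is new or still open speak of the compounds shown alone.

Measured compounds:
Compound 1, `Nc1ccccc1NC(=O)c1ccc(CSc2nccc(C(F)(F)F)n2)cc1` — in a functional assay on A549 cells (Homo sapiens) for inhibition, read by CCK-8 assay, with a stated time of 72 h, tested at 8 uM (a lower number here means less inhibition of growth, a higher number more inhibition of growth at the concentration tested), compound 1 gives 95.1%.
Compound 2, `Nc1ccccc1NC(=O)c1ccc(CSc2ccc(Br)cc2)cc1` — in this assay compound 2 gives 45.7%.
Compound 3, `Nc1ccccc1NC(=O)/C=C/c1ccc(CSc2cccc(F)c2)cc1` — in this assay compound 3 gives 56.6%.

Among these three, compound 2 stands lowest. Its nearest neighbour is compound 3, whose number lies beyond the scatter above it, and its furthest is compound 1, far above it. No two of these compounds differ in only one place, so no single step between measured compounds can be read off; the values are simply what they are.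

Compound 4, `Nc1ccccc1NC(=O)c1ccc(CSc2ccc(F)cc2)cc1`, has not yet been measured in this assay. It differs from compound 2 in one place: fluoro in place of bromo on an aromatic carbon. Going by the values given here, nothing among the measured compounds shows how this exchange of one halogen for another at this position behaves in this assay; compound 3 carries a fluoro but on a different core, so it cannot serve as a guide for the size of the step.

Among the compounds with values here, with no comparable step available, the step from compound 2 to compound 4 is expected to be small, a number 3.7 percentage points lower from compound 2 to compound 4 (within the scatter), and not clearly beyond the scatter in either direction. Compound 4 is therefore estimated at 42%, with a range from 25% to 60%.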

Compound 4, percent growth inhibition at one concentration: 44.5%
Estimate against measurement, compound 4: 2.5 percentage points below, within the range that was stated.
By their numbers in this assay, from the lowest: compounds 4 and 2 (each within the scatter of the next); then compound 3; then compound 1.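

In this assay, fluoro in place of bromo on an aromatic carbon, para to a large group, gives a number 1.2 percentage points lower from compound 2 to compound 4 (within the scatter), so the exchange of these two halogens at this position leaves no readable change in growth inhibition at the concentration tested. Going by these compounds alone, this is the first step in the set that isolates one place, and it shows that the size of the halogen atom's replacement here, from bromo to fluoro, does not carry the number beyond the usual scatter of the read-out. Nothing measured here explains why the two halogens give values within the scatter of each other.

The compounds shown leave open whether other groups at this same place, such as an amine, a carboxylic acid, a methoxy group or plain hydrogen, would give a step beyond the scatter, or whether this position tolerates change more generally. Steps to compound 1 and compound 3 cannot be read, since each differs from compound 2 and compound 4 in more than one place, so what sets their numbers apart remains unassigned.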